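The source may report more compounds than this note shows. Statements on the series, on what has been measured and on what is new or still open speak of the compounds shown alone.

In a physicochemical assay for solubility, at pH 7.4 (a higher number here means a more soluble compound, a lower number a less soluble compound), compound 1 `Cc1cc(NC(=O)Nc2ccc(C(C)(C)C)cc2)c2ccccc2n1` gives 6200 nM, the highest of the three numbers measured. Compound 2 `Cc1cc(NC(=O)Nc2ccc(F)c(F)c2)c2ccccc2n1` gives 500 nM, and compound 3 `Cc1cc(NC(=O)Nc2cccc(F)c2)c2ccccc2n1` gives 100 nM, so compound 1 stands well above both, with compound 2 nearer to it and compound 3 furthest away. Among the measured compounds shown here, the one step between measured compounds that differ in a single place, a 5.0-fold lower number from compound 2 to compound 3 (0.70 log units; beyond the scatter), concerns hydrogen in place of fluoro on an aromatic carbon. Compound 4 `COc1ccc(NC(=O)Nc2cc(C)nc3ccccc23)cc1` differs from compound 1 by methoxy in place of tert-butyl on an aromatic carbon. No measured step shows this exchange, and the single step shown concerns a fluoro rather than a tert-butyl or a methoxy, so it bears on the change only loosely. What the three compounds do show is that compound 1, carrying the tert-butyl, stands highest. On that ground the step is expected to be a modest lowering, a 2.5-fold lower number from compound 1 to compound 4 (0.39 log units; beyond the scatter), though it could also fall within the scatter. Compound 4 is therefore estimated at 2500 nM, with a range from 500 nM to 12000 nM.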

Compound 4, solubility: 19800 nM
For compound 4 the middle estimate is 7.9-fold (0.90 log units) below the measured one, and the stated range ends below it.
By their numbers in this assay, from the lowest: compound 3; then compound 2; then compound 1; then compound 4.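

In this assay, methoxy in place of tert-butyl on an aromatic carbon, para to a large group, gives a 3.2-fold higher number from compound 1 to compound 4 (0.50 log units; beyond the scatter), so the high number of compound 1 does not depend on keeping the tert-butyl at this position. Among the compounds shown here, the change replaces 4 heavy atoms, all carbon, with 2 heavy atoms, one of them oxygen, and it brings in a hydrogen-bond acceptor, an exchange that the fluoro step among the earlier compounds did not cover. Nothing measured here explains why the number rises, and no outside finding bears on it.

Open, as far as these compounds go, is which part of the exchange matters: the loss of the tert-butyl, or the arrival of the oxygen. From the compounds shown here alone, it also remains open how an ethoxy, a hydroxyl, an amine or a carboxylic acid at this place would compare with the methoxy of compound 4.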